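Swapping the aryl amide for cyclopropyl: a clearance outlook

A few compounds are considered here, and "the series" means these few. Any claim that something is new, unique, unknown or untested is made for them only; others in the source may bear on it.

Three measured compounds share one core and differ only in the group on an amide-type nitrogen. Compound 1 `CN1C[C@H](C(=O)Nc2cccc(F)c2)[C@@H](c2ccc(/C=C/C(=O)Nc3ccccc3N)cc2)C1` in an in vitro ADME assay on microsomes from liver (Homo sapiens) for pharmacokinetics, read by LC-MS, with a stated time of 10 min, tested at 1 uM (on this read-out lower numbers stand for slow clearance and higher numbers for fast clearance), gives 6 mL/min/kg. Compound 2 `Cc1cccc(NC(=O)[C@H]2CN(C)C[C@@H]2c2ccc(/C=C/C(=O)Nc3ccccc3N)cc2)c1` gives 14 mL/min/kg, and compound 3 `COc1cccc(NC(=O)[C@H]2CN(C)C[C@@H]2c2ccc(/C=C/C(=O)Nc3ccccc3N)cc2)c1` gives 14 mL/min/kg. Compound 3 thus stands level with compound 2, the two together being the highest of the three numbers; the only gap beyond the scatter is a 2.3-fold higher number from compound 1 to compound 3 (0.37 log units; beyond the scatter), matched in size by a 2.3-fold higher number from compound 1 to compound 2 (0.37 log units; beyond the scatter), while no change at the digits printed from compound 2 to compound 3 (within the scatter).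

Compound 4 `CN1C[C@H](C(=O)NC2CC2)[C@@H](c2ccc(/C=C/C(=O)Nc3ccccc3N)cc2)C1` is not yet measured. Its change from compound 3 is cyclopropyl in place of 3-methoxyphenyl on an amide-type nitrogen. Within the data shown here, no measured step covers removing the aromatic ring itself: each step seen swaps one small group for another on that ring, and each moved the number only modestly or not at all. What this change will do is therefore open, and the expectation is a small step in either direction inside a wide band, estimated as a 1.4-fold lower number from compound 3 to compound 4 (0.15 log units; within the scatter). Compound 4 is expected to give about 10 mL/min/kg, with a range from 4 mL/min/kg to 25 mL/min/kg.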

Compound 4, clearance: 10 mL/min/kg
Estimate against measurement, compound 4: no gap at the digits printed; low and high end bracket the measured number.
By their numbers in this assay, from the lowest: compounds 1, 4, 2 and 3 (each within the scatter of the next, the first and the last beyond it).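

In this assay, among these compounds, cyclopropyl is the first group on this amide-type nitrogen that removes the aromatic ring altogether, and the number stays within the scatter of all three aryl amides (a 1.4-fold lower number from compound 3 to compound 4 (0.15 log units; within the scatter); a 1.4-fold lower number from compound 2 to compound 4 (0.15 log units; within the scatter); a 1.7-fold higher number from compound 1 to compound 4 (0.22 log units; within the scatter)). Among these four compounds, then, an aromatic ring at this position is not needed for a clearance in this range, and compound 4 cannot be told apart from either the lowest or the highest compound. No measurement here explains why this result occurs.

On these data alone, whether an open-chain group such as isopropyl or a longer chain would behave in the same way remains open. So does the effect of placing an amine or a carboxylic acid on the group at this nitrogen.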